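This account rests on a few compounds, and the source may have more. Where it says the series, first, only, none or still open, it means among the compounds named here.

Working notes on the series, read-out an ADME assay for pharmacokinetics (on this read-out lower numbers stand for a shorter-lived compound and higher numbers for a longer-lived compound), so far. Compound 1 (`CC[C@H](c1ccc(O)cc1)[C@@H](CC)c1ccc(OCC(O)CBr)cc1`) gives 0.5 h, and compound 2 (`CC[C@H](c1ccc(O)cc1)[C@@H](CC)c1ccc(CBr)cc1`) gives 2.5 h as the higher of the two numbers. Still unmeasured is compound 3 (`CC[C@H](c1ccc(O)cc1)[C@@H](CC)c1ccc(OCC(O)CCl)cc1`), whose change from compound 2 is 3-chloro-2-hydroxypropoxy in place of bromomethyl on an aromatic carbon, para to a large group (3-chloro-2-hydroxypropoxy in place of bromomethyl on an aromatic carbon). For the measured compounds named here, the one measured step that bears on this is bromomethyl in place of 3-bromo-2-hydroxypropoxy (a 5.0-fold higher number from compound 1 to compound 2 (0.70 log units; beyond the scatter)). Going by the values given here, compound 3 runs that exchange in reverse, except that chlorine stands where compound 1 has bromine in the chain, and no measured pair covers that halogen exchange. A step of about the same size, toward a lower number, is therefore expected in this assay for compound 3, with a wide margin. The estimated step is as follows (a 3.6-fold lower number from compound 2 to compound 3 (0.55 log units; beyond the scatter)). For compound 3 the estimate is 0.7 h as the expected value, with an expected range from 0.35 h to 1.5 h for repeat measurements.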

Compound 3, half-life: 0.5 h
Compound 3: middle estimate off by 1.4-fold (0.15 log units), on the high side; measured number inside the range.
By their numbers in this assay, from the lowest: compounds 1 and 3 (each within the scatter of the next); then compound 2.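

In this assay, 3-chloro-2-hydroxypropoxy in place of bromomethyl on the aromatic carbon gives a 5.0-fold lower number from compound 2 to compound 3 (0.70 log units; beyond the scatter), a step of the same size as a 5.0-fold higher number from compound 1 to compound 2 (0.70 log units; beyond the scatter), run in the opposite direction. Chloro in place of bromo on the saturated chain carbon gives no change at the digits printed from compound 1 to compound 3 (within the scatter), so the two halogens on the hydroxypropoxy chain cannot be told apart on this read-out. Across these three compounds, with none going against it, the gap follows the exchange between bromomethyl and a halogenated hydroxypropoxy chain rather than the identity of the halogen, since compound 1 and compound 2 both carry bromine yet sit apart.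

Nothing available gives a reason for either step. On these data alone, the chain differs from bromomethyl in its oxygens, its hydroxyl and its length all at once, so it remains open which of these parts goes with the gap, and whether a chain ending in an amine or a carboxylic acid, or a plain longer carbon chain, would fall with compound 2 or with compound 1 and compound 3.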